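Moving the methoxy group: compound 3 to compound 4

The compounds below may be only part of what the source reports. "The series", "measured", "known", "first", "only" and "open" are said of these compounds alone.

Measured so far:
compound 1 `COc1ccc(-c2c(S(=O)(=O)c3cccc(C#N)c3)cnc3cc(F)ccc23)cc1` — 0.92 mL/min
compound 2 `COc1ccc(-c2c(S(=O)(=O)c3cc(F)cc(F)c3)cnc3cc(F)ccc23)cc1` — 1.51 mL/min
compound 3 `COc1cccc(-c2c(S(=O)(=O)c3cc(Cl)cc(Cl)c3)cnc3cc(F)ccc23)c1` — 1.51 mL/min

In an ADME assay on microsomes from liver (Homo sapiens) for metabolic stability, tested at 2.5 uM (a higher number here means faster removal of the compound, a lower number slower removal), compound 3 gives 1.51 mL/min, level with compound 2 at the digits shown and together the highest of the three numbers; compound 1 sits at 0.92 mL/min, within the scatter of both. Compound 4 `COc1ccc(-c2c(S(=O)(=O)c3cc(Cl)cc(Cl)c3)cnc3cc(F)ccc23)cc1` is not yet measured. It differs from compound 3 in one place: 4-methoxyphenyl in place of 3-methoxyphenyl on an aromatic carbon. The group that leaves and the group that enters have the same atoms, joined differently. Among the measured compounds shown here, no measured step touches this position; the only step, a 1.6-fold higher number from compound 1 to compound 2 (0.22 log units; within the scatter), changes the ring on the sulfonyl sulfur and lies within the scatter, and all three numbers fall within the scatter of one another. The expected step is therefore a 1.1-fold lower number from compound 3 to compound 4 (0.03 log units; within the scatter), nothing beyond the scatter. For compound 4 the estimate is 1.4 mL/min, with a range from 0.7 mL/min to 2.8 mL/min.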

Compound 4, intrinsic clearance in a liver preparation (reported as CLH), per the amount of preparation that the assay uses: 1 mL/min
Beside the measured number, compound 4's estimate is 1.4-fold (0.15 log units) above it; low and high end bracket the measured number.
By their numbers in this assay, from the lowest: compounds 1, 4, 2 and 3 (each within the scatter of the next).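

Moving the methoxy group gives the first read on this position: in this assay the swap to 4-methoxyphenyl is a 1.5-fold lower number from compound 3 to compound 4 (0.18 log units; within the scatter) and leaves the number within the scatter. With 4-methoxyphenyl held in place, the sulfonyl ring changes give a 1.5-fold lower number from compound 2 to compound 4 (0.18 log units; within the scatter) and a 1.1-fold higher number from compound 1 to compound 4 (0.04 log units; within the scatter), so neither reading separates the compounds. No evidence is available to explain these steps. Still open, as far as these compounds go, is whether an amine or a carboxylic acid in place of the methoxy group would give a step beyond the scatter.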